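The compounds below may be only part of what the source reports. "The series", "measured", "known", "first", "only" and "open" are said of these compounds alone.

Compound 1, with structure `COc1cccc2cc(C(=O)NC3CCCC3)c(=N)oc12`, gives 47% in an assay on HEK293 cells for displacement of a labelled ligand from adenosine receptor A2b (Homo sapiens), read by scintillation counting, with a stated time of 30 min, tested at 10 uM (on this read-out lower numbers stand for less inhibition and higher numbers for more inhibition at the one concentration tested (going by the name of the read-out)), and this is the highest of the three numbers measured. Compound 2, `N=c1oc2ccc(Br)cc2cc1C(=O)NC1CCCC1`, gives 28% in this assay, a value that lies beyond the scatter below compound 1. Compound 3, `N=c1oc2ccc(Br)cc2cc1C(=O)NCCCO`, gives 25% in this assay, the furthest below compound 1. For the measured compounds named here, the one single-point step among the measured compounds is a number 3 percentage points lower from compound 2 to compound 3 (within the scatter), which lies within the scatter. Compound 4, `COc1cccc2cc(C(=O)NC(CO)(CO)CO)c(=N)oc12`, has not yet been measured; it differs from compound 1 by 2-hydroxy-1,1-bis(hydroxymethyl)ethyl in place of cyclopentyl on an amide-type nitrogen. Going by the values given here, the only measured step that bears on this change is the one from compound 2 to compound 3, where a cyclopentyl on an amide-type nitrogen was also exchanged for a hydroxyl-bearing chain with essentially no movement in the number. The change to compound 4 is larger in kind than that step, so a modest decrease is expected rather than none, and the estimated step is a number 15 percentage points lower from compound 1 to compound 4 (beyond the scatter). Compound 4 is therefore expected to give 32% in this assay, within a range from 12% to 50%.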

Compound 4, a percentage reported as inhibition, at one concentration (the size of the read-out at that concentration, not a potency): 28%
Compound 4: the middle estimate sits 4 percentage points above what was measured, within the range that was stated.
By their numbers in this assay, from the lowest: compounds 3, 2 and 4 (each within the scatter of the next); then compound 1.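

In this assay the group on the amide-type nitrogen now produces a step beyond the scatter: a number 19 percentage points lower from compound 1 to compound 4 (beyond the scatter) when 2-hydroxy-1,1-bis(hydroxymethyl)ethyl takes the place of cyclopentyl. The earlier exchange at this nitrogen, a number 3 percentage points lower from compound 2 to compound 3 (within the scatter) on a different core, lay within the scatter, so this position is shown for the first time not to be indifferent to what it carries, at least on the core of compound 1. Nothing measured here accounts for the step.

The change removes a carbon-only ring and brings in hydroxyl groups together, and the compounds shown do not separate these two events. Also open, from the compounds shown here alone, is how a simple amine or a carboxylic acid on this nitrogen would read in this assay on the core of compound 1.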